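The source may report more compounds than this note shows. Statements on the series, on what has been measured and on what is new or still open speak of the compounds shown alone.

Compound 1 `Cn1ccc2ccc(-c3cc(Nc4cnccc4C(=O)NCc4cncnc4)cc4nccnc34)cc21` gives 49500 nM in an assay on lysate for inhibition of 6-phosphofructo-2-kinase/fructose-2,6-bisphosphatase 3 (Homo sapiens), with stated times of 0.5 min and 45 min; on this read-out lower numbers stand for stronger inhibition and higher numbers for weaker inhibition. Compound 2 `Cn1cc(CNC(=O)c2ccncc2Nc2cc(-c3ccc4ccn(C)c4c3)c3nccnc3c2)cn1` gives 75900 nM in this assay. Compound 3 `CC(=O)N1CCCC(NC(=O)c2ccncc2Nc2cc(-c3ccc4ccn(C)c4c3)c3nccnc3c2)C1` gives 13500 nM in this assay.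

Compound 3 stands lowest of the three: the steps of a 3.7-fold lower number from compound 1 to compound 3 (0.56 log units; beyond the scatter) and a 5.6-fold lower number from compound 2 to compound 3 (0.75 log units; beyond the scatter) both lie beyond the scatter. Compound 4 `CN1CC(NC(=O)c2ccncc2Nc2cc(-c3ccc4ccn(C)c4c3)c3nccnc3c2)CCC1=O` differs from compound 3 by 1-methyl-6-oxopiperidin-3-yl in place of 1-acetylpiperidin-3-yl on an amide-type nitrogen. Going by the values given here, no measured step exchanges one saturated ring for another on that amide nitrogen; the measured steps swap aromatic groups for each other or for the 1-acetylpiperidin-3-yl group, so they bear only loosely on this change. Compound 4 is therefore expected to land near compound 3, with no step beyond the scatter, a 1.0-fold higher number from compound 3 to compound 4 (0.02 log units; within the scatter). Compound 4 is estimated at 14000 nM, in the range 5000 nM to 40000 nM.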

Compound 4, half-maximal inhibitory concentration: 96500 nM
For compound 4 the middle estimate is 6.9-fold (0.84 log units) below the measured one, outside the stated range (above it).
By their numbers in this assay, from the lowest: compound 3; then compounds 1, 2 and 4 (each within the scatter of the next).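

On the amide-type nitrogen, a saturated ring alone does not keep the lower number seen in this assay: the two groups share one six-membered non-aromatic ring and the same donor and acceptor counts, yet the exchange gives a clear step (a 7.1-fold higher number from compound 3 to compound 4 (0.85 log units; beyond the scatter)). The other two steps (a 1.3-fold higher number from compound 2 to compound 4 (0.10 log units; within the scatter)) (a 1.9-fold higher number from compound 1 to compound 4 (0.29 log units; within the scatter)) lie within the scatter, so the 1-methyl-6-oxopiperidin-3-yl group does not share the advantage of the 1-acetylpiperidin-3-yl group over the aromatic groups. No measured evidence accounts for this difference.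

From the compounds shown here alone, it remains open whether an unsubstituted piperidin-3-yl amine or a 1-acetylpyrrolidin-3-yl group on that nitrogen would track compound 3 or compound 4.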